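The source may hold more compounds than are shown below. What is called first, only, known or untested is meant among the compounds shown, and "the series" means these compounds.

The study concerns a small set of amides built on a shared core, tested in a toxicity assay on THP-1 cells (Homo sapiens) for inhibition; on this read-out higher numbers stand for lower toxicity in this test and lower numbers for higher toxicity in this test. Compound 1 `COc1ccc(-c2cnc(NC(=O)c3ccc(F)cc3)n2Cc2ccccc2)cc1` is an aromatic amide with a benzyl substituent on the core. In this assay compound 1 reaches only the limit of the test, > 100000 nM. Compound 3 `Cn1c(-c2ccccc2[N+](=O)[O-])cnc1NC(=O)c1ccc(F)cc1` is a related aromatic amide, and in this assay compound 3 gives 31000 nM, a measured number rather than a limit. Compound 2 `COc1ccc(-c2cnc(NC(=O)C3CCNCC3)n2C)cc1` differs from both in carrying a non-aromatic amide. In this assay compound 2 likewise gives only a limit, > 100000 nM. Compound 2 therefore stands at the limit of > 100000 nM in this assay, at which 2 of the 3 values shown sit, so its exact toxicity is not known, only that it lies beyond the measured range.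

Compound 4 `COc1ccc(-c2cnc(NC(=O)c3cccc(Cl)c3)n2C)cc1` is the compound still to be measured. It differs from compound 2 in one place: 3-chlorophenyl in place of piperidin-4-yl on a carbonyl carbon. Among the compounds with values here, no measured step in this set connects two compounds that differ at this position alone, so no direct precedent exists. The aromatic amides compound 1 and compound 3 show one limit and one measured value, which leaves the direction open. Compound 4 is expected to sit close to or at the limit, with a step from compound 2 of about an at least 1.2-fold lower number from compound 2 to compound 4 (0.09 log units; that floor lies within the scatter), not clearly beyond the scatter. The estimate for compound 4 is 80000 nM, within a range of 30000 nM to 200000 nM.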

Compound 4, half-maximal cytotoxic concentration: > 28000 nM
Compound 4: a limit, no number; the forecaster's own chance of this, stated with the estimate: 55%; the middle value does not contradict the limit.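

Within the data shown here, compound 2 and compound 4 both return only limits in this assay, and no step between them can be read. The compounds shown leave open where the actual values of compound 2 and compound 4 lie, and whether 3-chlorophenyl in place of piperidin-4-yl on a carbonyl carbon changes the read-out at all.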